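This account rests on a few compounds, and the source may have more. Where it says the series, first, only, none or still open, it means among the compounds named here.

Measured so far:
compound 1 `O=C(Nc1ncc(Cc2cccc3ccoc23)s1)C1CCCCC1`, > 40000 nM in an ADME assay on P388D1 cells (Mus musculus) for cytotoxicity, read by fluorescence and resazurin assay, with a stated time of 72 h; on this read-out higher numbers stand for weaker inhibition and lower numbers for stronger inhibition
compound 2 `O=C(CCC1CCCCC1)Nc1ncc(Cc2cccc3ccoc23)s1`, 17800 nM in this assay
compound 3 `O=C(Nc1ncc(Cc2cccc3c2CCC3)s1)C1CCCCC1`, > 40000 nM in this assay

The value of compound 1 is a limit of the assay, not a number. The value of compound 3 is likewise a limit. Two of the three values sit at this limit (the limit of > 40000 nM in this assay, at which 2 of the 3 values shown sit). Among the measured compounds shown here, the one counted change, (2-cyclohexylethyl in place of cyclohexyl on a carbonyl carbon), gave an at least 2.2-fold lower number from compound 1 to compound 2 (0.35 log units; beyond the scatter). The core of compound 3 differs from that of compound 1 in a way not broken down here. Compound 4 `O=C(CCC1CCCCC1)Nc1ncc(Cc2cccc3c2CCC3)s1` carries the same kind of change on the core of compound 3: 2-cyclohexylethyl in place of cyclohexyl on a carbonyl carbon. In this assay the step is expected to be an at least 1.6-fold lower number from compound 3 to compound 4 (0.20 log units; that floor lies within the scatter), resting on compound 1 to compound 2 alone, with the reservation that compound 3 starts from a limit. Compound 4 is therefore estimated at 25000 nM, between 9000 nM and 80000 nM.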

Compound 4, half-maximal inhibitory concentration: > 40000 nM
Compound 4 gave a limit, no number (the forecaster's own chance of this, stated with the estimate: 45%); at least 1.6-fold (0.20 log units) between middle value and limit.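

Compound 3 and compound 4 both give only a limit, so no step can be read between them: the limit of > 40000 nM in this assay, at which 3 of the 4 values shown sit.

The compounds shown leave open whether 2-cyclohexylethyl in place of cyclohexyl on a carbonyl carbon changes the number on the core of compound 3 in this assay.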